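A Methyl Step Repeated on the Thiourea Analog

A few compounds are considered here, and "the series" means these few. Any claim that something is new, unique, unknown or untested is made for them only; others in the source may bear on it.

Three compounds have been measured in a functional assay on RS4-11 cells (Homo sapiens) for inhibition, read by CCK-8 assay, with a stated time of 48 h; on this read-out lower numbers stand for stronger inhibition and higher numbers for weaker inhibition:

compound 1 `Cc1ccc(-c2ccsc2S(=O)(=O)NCCNC(=O)Nc2cc(C(F)(F)F)cc(C(F)(F)F)c2)c(Oc2ccc(O)c(O)c2)c1` gives 5600 nM;
compound 2 `O=C(NCCNS(=O)(=O)c1sccc1-c1ccccc1Oc1ccc(O)c(O)c1)Nc1cc(C(F)(F)F)cc(C(F)(F)F)c1` gives 4900 nM;
compound 3 `O=S(=O)(NCCNC(=S)Nc1cc(C(F)(F)F)cc(C(F)(F)F)c1)c1sccc1-c1ccccc1Oc1ccc(O)c(O)c1` gives 4800 nM.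

Compound 1 differs from compound 2 by methyl in place of hydrogen on an aromatic carbon. That change made a 1.1-fold higher number from compound 2 to compound 1 (0.06 log units; within the scatter). Compound 3 carries a thiourea where compound 2 carries a urea; the difference between the two cores is not broken down here, and the values of compound 2 and compound 3 lie within the scatter of each other, as do those of all three measured compounds.

Compound 4 `Cc1ccc(-c2ccsc2S(=O)(=O)NCCNC(=S)Nc2cc(C(F)(F)F)cc(C(F)(F)F)c2)c(Oc2ccc(O)c(O)c2)c1` is not yet measured in this assay. It differs from compound 3 by methyl in place of hydrogen on an aromatic carbon. The surroundings of the place are the same word for word as in the change from compound 2 to compound 1, so this is the same change made on the core of compound 3.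

For compound 4 the expected step is a 1.1-fold higher number from compound 3 to compound 4 (0.05 log units; within the scatter), a step that is estimated to stay within the scatter because the same change gave a 1.1-fold higher number from compound 2 to compound 1 (0.06 log units; within the scatter). Compound 4 is therefore estimated at 5400 nM, with a likely range from 2500 nM to 12000 nM.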

Compound 4, half-maximal inhibitory concentration: 4800 nM
Compound 4: the middle estimate sits 1.1-fold (0.05 log units) above what was measured; low and high end bracket the measured number.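

In this assay, methyl in place of hydrogen on the aromatic carbon gave no change at the digits printed from compound 3 to compound 4 (within the scatter). Set beside the earlier step, the change reads the same on the two cores: the same change on two cores in this assay, a 1.1-fold higher number (0.06 log units; within the scatter) from compound 2 to compound 1 and no change at the digits printed (within the scatter) from compound 3 to compound 4, 1.1-fold (0.06 log units) apart, within the scatter of two such steps This shows that, on these two cores, the methyl carries from the core of compound 2 to the core of compound 3 with no step beyond the scatter, but it does not show that the methyl has any effect of its own on this read-out, and two cores say nothing about how the change would behave on a third.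

The compounds shown hold only hydrogen or methyl at this place on the ring, so it remains open whether a different group there, such as a chlorine, a methoxy group or an amine, would give a step beyond the scatter. As far as these compounds go, it also remains open whether such a group would give the same step on the core of compound 2 and on the core of compound 3.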